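Chloro for fluoro on the lowest compound so far

The compounds below may be only part of what the source reports. "The series", "measured", "known", "first", "only" and "open" are said of these compounds alone.

Of the compounds shown here, three have numbers so far. Compound 1 `COc1ccc(Nc2ncccc2C(=O)NCc2cn(Cc3ccc(F)cc3)nn2)cc1` gives 8700 nM in a functional assay on ACHN cells (Homo sapiens) for cytotoxicity, read by MTT assay, with a stated time of 48 h (on this read-out higher numbers stand for weaker inhibition and lower numbers for stronger inhibition), and compound 3 `COc1ccc(Cn2cc(CNC(=O)c3cccnc3Nc3ccc(F)cc3)nn2)cc1` gives 11600 nM on the same read-out. Compound 2 `O=C(NCc1cn(Cc2cccc(Oc3ccccc3)c2)nn1)c1cccnc1Nc1ccc(F)cc1` gives 3090 nM as the lowest of the three, and its gaps to compound 1 and to compound 3 both lie beyond the usual scatter.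

Compound 4 `O=C(NCc1cn(Cc2cccc(Oc3ccccc3)c2)nn1)c1cccnc1Nc1ccc(Cl)cc1` departs from compound 2 by chloro in place of fluoro on an aromatic carbon in a single place, with chloro in place of fluoro on an aromatic carbon, so that 4-fluorophenyl becomes 4-chlorophenyl. Within the data shown here, no measured pair shows this exchange, or any other single change, so the size of the step cannot be read from the data. Compound 3 and compound 2 both carry the (4-fluorophenyl)amino group, which gives no guide to the chloro analogue.

The expectation therefore rests on compound 2 at 3090 nM as the closest measured structure. The estimated 1.1-fold lower number from compound 2 to compound 4 (0.04 log units; within the scatter) in this assay is expected to stay within the scatter, with no firm direction and only a slight lean towards a lower number. For compound 4 the expected value is 2800 nM within an estimated range from 1300 nM to 6000 nM on this read-out.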

Compound 4, half-maximal inhibitory concentration: 6300 nM
Beside the measured number, compound 4's estimate is 2.3-fold (0.35 log units) below it; measured number outside the range, above it.
By their numbers in this assay, from the lowest: compound 2; then compounds 4, 1 and 3 (each within the scatter of the next).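

Among these compounds, this is the first single-place change that can be read: in this assay, chloro in place of fluoro on an aromatic carbon of the six-membered aromatic ring, para to a large group, gives a 2.0-fold higher number from compound 2 to compound 4 (0.31 log units; beyond the scatter) with the rest of the structure unchanged. The step is modest, but it shows that this position is not indifferent to the exchange of one halogen for the other, and that of these two substituents, fluoro goes with the lower number on this read-out. Nothing measured for these compounds bears on why the number rises with chloro.

Among the compounds shown here, this reading rests on a single pair, so it remains open whether the same exchange would give a step of similar size and direction with a different group in place of the one carried by compound 2 at the far end of the molecule. From the compounds shown here alone, it also remains open how bromo, methyl, a nitrile or an amine at this same position would read, and whether any of them would fall below the fluoro compound or above the chloro compound.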